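A 2-phenylethenyl group in place of 2,4-difluorophenyl

The source may hold more compounds than are shown below. What is called first, only, known or untested is meant among the compounds shown, and "the series" means these compounds.

Compound 1 (`O=C1C(=Cc2ccc(Br)cc2)C(=O)N(c2ccc(Cl)cc2)N1c1ccc(Cl)cc1`), compound 2 (`O=C1C(=Cc2cccc(Cl)c2)C(=O)N(c2ccc(Cl)cc2)N1c1ccc(Cl)cc1`) and compound 3 (`O=C1C(=Cc2ccc(F)cc2F)C(=O)N(c2ccc(Cl)cc2)N1c1ccc(Cl)cc1`) share one core and differ only in the substituted phenyl group on a double-bonded chain carbon bound to a double-bonded ring carbon. In a functional assay on ECa-109 cells (Homo sapiens) for cytotoxicity, read by MTT assay, with a stated time of 72 h (a lower number here means a stronger inhibitor, a higher number a weaker inhibitor), compound 1 gives 12300 nM, compound 2 gives 22600 nM and compound 3 gives 13100 nM. Compound 3 is not separated from the other two, with steps of a 1.1-fold higher number from compound 1 to compound 3 (0.03 log units; within the scatter) and a 1.7-fold lower number from compound 2 to compound 3 (0.24 log units; within the scatter). The remaining step, a 1.8-fold higher number from compound 1 to compound 2 (0.26 log units; within the scatter), is no different in kind.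

Compound 4 (`O=C1C(=C/C=C/c2ccccc2)C(=O)N(c2ccc(Cl)cc2)N1c1ccc(Cl)cc1`) departs from compound 3 by one change, (2-phenylethenyl in place of 2,4-difluorophenyl on a double-bonded chain carbon bound to a double-bonded ring carbon), with 2-phenylethenyl in place of 2,4-difluorophenyl at that same place. All three measured steps were made there and bear on this change, but none of them introduces a 2-phenylethenyl group. No step beyond the scatter is therefore expected in this assay, and no direction can be favoured, though the range is kept wide. The expected step is a 1.1-fold higher number from compound 3 to compound 4 (0.03 log units; within the scatter). For compound 4 the estimated value is 14000 nM, with an expected range of 6000 nM to 32000 nM.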

Compound 4, half-maximal inhibitory concentration: 9900 nM
Beside the measured number, compound 4's estimate is 1.4-fold (0.15 log units) above it; measured number inside the range.
By their numbers in this assay, from the lowest: compounds 4, 1, 3 and 2 (each within the scatter of the next, the first and the last beyond it).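

The place on a double-bonded chain carbon bound to a double-bonded ring carbon proves to accept more than a directly attached substituted phenyl group: with 2-phenylethenyl, which brings a double bond outside aromatic rings, this assay gives a 1.3-fold lower number from compound 3 to compound 4 (0.12 log units; within the scatter) and a 1.2-fold lower number from compound 1 to compound 4 (0.09 log units; within the scatter) as steps that both stay within the scatter. Only the comparison with the 3-chlorophenyl compound leaves the scatter, with a 2.3-fold lower number from compound 2 to compound 4 (0.36 log units; beyond the scatter) as a modest step and the first in this set to do so. No measurement at hand explains this result.

As far as these compounds go, whether an amine, a carboxylic acid or a longer chain at this place would move the number in this assay stays open. So does whether a substituent on the phenyl ring of the 2-phenylethenyl group would take compound 4 beyond the scatter.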